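The compounds below may be only part of what the source reports. "The series", "measured", "known", "first", "only" and "open" are said of these compounds alone.

Compound 1 `CC(C)c1ccccc1OS(=O)(=O)c1ccc(NC(=O)CCl)cc1` gives 2900 nM in a functional assay on MCF7 cells (Homo sapiens) for antiproliferative activity, read by sulforhodamine B assay, with a stated time of 48 h; on this read-out higher numbers stand for weaker inhibition and lower numbers for stronger inhibition. Compound 2 `CC(C)c1ccccc1OS(=O)(=O)c1ccc(NC(=O)NC2CCCC2)cc1` gives 6200 nM in this assay.

Within this pair, compound 2 stands at the higher end: the only measured step, a 2.1-fold higher number from compound 1 to compound 2 (0.33 log units; beyond the scatter), runs from compound 1 to it, so compound 2 is the weaker of the two on this read-out. Compound 3 `CC(C)c1ccccc1OS(=O)(=O)c1ccc(NC(=O)NCC2CCCC2)cc1` has not yet been measured. It differs from compound 2 only at the urea end, where (cyclopentylmethyl in place of cyclopentyl on an amide-type nitrogen). That is a homologation by a single carbon between the ring and the amide-type nitrogen, leaving donors and acceptors unchanged. Within the data shown here, no measured step matches this change; the one step available, a 2.1-fold higher number from compound 1 to compound 2 (0.33 log units; beyond the scatter), concerns the swap of chloromethyl for cyclopentylamino and says nothing about lengthening the chain behind the nitrogen. Among the measured compounds shown here, with no step bearing on it, compound 3 is expected to stay close to compound 2, with a 1.0-fold lower number from compound 2 to compound 3 (0.01 log units; within the scatter) lying within the scatter. The estimate for compound 3 is therefore 6000 nM, in the range 2500 nM to 15000 nM.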

Compound 3, half-maximal inhibitory concentration: 7100 nM
Estimate against measurement, compound 3: 1.2-fold (0.07 log units) below; low and high end bracket the measured number.
By their numbers in this assay, from the lowest: compound 1; then compounds 2 and 3 (each within the scatter of the next).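

In this assay, putting cyclopentylmethyl in place of cyclopentyl on the amide-type nitrogen gives a 1.1-fold higher number from compound 2 to compound 3 (0.06 log units; within the scatter) and so leaves the two indistinguishable on this read-out, which shows that this end of the urea tolerates the change from cyclopentyl to cyclopentylmethyl without a measurable shift. Set against the chloromethyl group on the carbonyl carbon of compound 1, the (cyclopentylmethyl)amino group gives a 2.4-fold higher number from compound 1 to compound 3 (0.39 log units; beyond the scatter) and the cyclopentylamino group gives a 2.1-fold higher number from compound 1 to compound 2 (0.33 log units; beyond the scatter) and thus both urea compounds sit on the higher side of compound 1, so the difference from compound 1 now rests on two compounds rather than one. No evidence at hand bears on why the cyclopentylmethyl group behaves as it does here.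

What the compounds shown leave open is how far this tolerance extends on the same nitrogen: a longer chain such as cyclopentylethyl, a larger ring such as cyclohexyl, or an aromatic ring such as phenyl might or might not keep the number in the same range. A urea carrying an amine or a carboxylic acid on that chain has not been measured. On these data alone, whether its number would match that of compound 1 is also open.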